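This account rests on a few compounds, and the source may have more. Where it says the series, first, only, none or still open, it means among the compounds named here.

Measured so far: compound 1 `COc1cc(N/C=C\C(=O)c2cn(-c3ccccc3)nc2-c2ccccc2)cc(OC)c1OC`, 9800 nM; compound 2 `COc1ccc(N/C=C\C(=O)c2cn(-c3ccccc3)nc2-c2ccc(Cl)cc2)cc1`, 8930 nM.

In a functional assay on HT-29 cells (Homo sapiens) for antiproliferative activity, read by MTT assay, with a stated time of 48 h (a higher number here means a weaker inhibitor, a lower number a stronger inhibitor), compound 1 holds the highest of the two numbers, though the gap to compound 2 lies within the scatter. Compound 3 `COc1cc(N/C=C\C(=O)c2cn(-c3ccccc3)nc2-c2cc(OC)c(OC)c(OC)c2)cc(OC)c1OC` differs from compound 1 in one place: 3,4,5-trimethoxyphenyl in place of phenyl on an aromatic carbon. For the measured compounds named here, no step between measured compounds is available to guide this change, so the account rests on compound 1 alone. In this assay compound 3 is expected to give 7000 nM (range 2500 nM to 20000 nM), the estimated step of a 1.4-fold lower number from compound 1 to compound 3 (0.15 log units; within the scatter) being a slight lowering, not clearly beyond the scatter.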

Compound 3, half-maximal inhibitory concentration: 8400 nM
Beside the measured number, compound 3's estimate is 1.2-fold (0.08 log units) below it, and the stated range covers the measured number.
By their numbers in this assay, from the lowest: compounds 3, 2 and 1 (each within the scatter of the next).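

In this assay the exchange of phenyl for 3,4,5-trimethoxyphenyl on this aromatic carbon gives a 1.2-fold lower number from compound 1 to compound 3 (0.07 log units; within the scatter) and thus does not separate the two compounds. For the compounds shown here, this is the first step at this position, and it shows that adding the three methoxy groups to the phenyl here has no effect that can be told from the scatter. Nothing measured on these compounds offers an explanation for this result. As far as these compounds go, whether an amine, a carboxylic acid or a longer chain on this carbon would give a step beyond the scatter stays open.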